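The compounds below may be only part of what the source reports. "The series", "measured", "known", "first", "only" and "open" are said of these compounds alone.

Measured compounds:
compound 1, `CC(=O)N1N=C(c2cccc3ccccc23)CC1c1cccc(Br)c1`: in a functional assay on IMR-32 cells (Homo sapiens) for cytotoxicity, read by sulforhodamine B assay, with a stated time of 48 h (a lower number here means a stronger inhibitor, a higher number a weaker inhibitor), compound 1 gives 11900 nM
compound 2, `CC(=O)N1N=C(c2cccc3ccccc23)CC1c1ccco1`: in this assay compound 2 gives 8000 nM
compound 3, `O=CCN1N=C(c2ccc3ccccc3c2)CC1c1cccc(Br)c1`: in this assay compound 3 gives 9870 nM

The change from compound 1 to compound 2 is furan-2-yl in place of 3-bromophenyl on a saturated ring carbon. It made a 1.5-fold lower number from compound 1 to compound 2 (0.17 log units; within the scatter). Compound 3 is built from the same atoms as compound 1, joined differently; the difference between the two cores is not broken down here. Its value in this assay sits close to those of compound 1 and compound 2, and all three lie within the usual scatter of one another, so no order among them can be stated.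

Compound 4 `O=CCN1N=C(c2ccc3ccccc3c2)CC1c1ccco1` has not yet been measured in this assay. It differs from compound 3 by furan-2-yl in place of 3-bromophenyl on a saturated ring carbon. This is the same kind of change as that from compound 1 to compound 2, though the surroundings are not identical: in compound 3 the saturated ring carbon is next to the ring atom that bears a formylmethyl group, whereas in compound 1 it is next to the ring atom that bears an acetyl group. Only one earlier instance of this change exists among these compounds, so the expectation rests on it alone. A step of similar size is expected, a 1.3-fold lower number from compound 3 to compound 4 (0.12 log units; within the scatter), because the same kind of change made a 1.5-fold lower number from compound 1 to compound 2 (0.17 log units; within the scatter). Compound 4 is expected to give about 7500 nM in this assay, with a likely range from 3500 nM to 16000 nM.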

Compound 4, half-maximal inhibitory concentration: 11000 nM
Beside the measured number, compound 4's estimate is 1.5-fold (0.17 log units) below it; low and high end bracket the measured number.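

In this assay, furan-2-yl in place of 3-bromophenyl on the saturated ring carbon gives a 1.1-fold higher number from compound 3 to compound 4 (0.05 log units; within the scatter). Set beside the earlier instance, the step on the second core shows no measurable difference from the first, so nothing here indicates that the outcome of this change depends on which of the two cores carries it: the same change on two cores in this assay, a 1.5-fold lower number (0.17 log units; within the scatter) from compound 1 to compound 2 and a 1.1-fold higher number (0.05 log units; within the scatter) from compound 3 to compound 4, 1.7-fold (0.22 log units) apart, within the scatter of two such steps. Among the compounds shown here, this does not show that a shared effect of the change carries over: each step lies within the scatter on its own, so the agreement is between two steps that cannot be told from no step at all, and two pairs say nothing about any further core.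

The compounds shown leave open whether any replacement on the saturated ring carbon can move the number beyond the scatter, for instance a ring bearing an amine or a carboxylic acid in place of 3-bromophenyl or furan-2-yl. Also open, going by these compounds, is what happens when the acetyl or formylmethyl group on the ring nitrogen gives way to a longer chain, and whether the present change would still behave alike on the two cores once a step large enough to read is available.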